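This account rests on a few compounds, and the source may have more. Where it says the series, first, only, none or still open, it means among the compounds named here.

Measured so far:
compound 1 `CCCCCOCCCCCCC/C=C1\CC(CO)(COC(=O)C(C)(C)C)OC1=O`: 2.96 ug/mL
compound 2 `CC(C)(C)C(=O)OCC1(CO)C/C(=C/CCCCCCCCCCCCCCC=O)C(=O)O1`: > 10 ug/mL

For the measured compounds named here, in a functional assay on HL-60 cells (Homo sapiens) for antiproliferative activity (a higher number here means a weaker inhibitor of growth, a lower number a stronger inhibitor of growth), compound 1 gives 2.96 ug/mL, the only actual number available so far. Compound 2 gives > 10 ug/mL, which is a limit of the assay and not a number. Compound 1 is therefore the sole numerical reference point for the series.

Compound 3 `CC(=O)NCCCCCCCCCCCCCCC/C=C1\CC(CO)(COC(=O)C(C)(C)C)OC1=O` has not yet been measured. Its structural change from compound 1 is 8-acetamidooctyl in place of pentyloxy on a saturated chain carbon, seven bonds along the chain from a double-bonded chain carbon. In words, 8-acetamidooctyl stands in place of pentyloxy on a saturated chain carbon, seven bonds along the chain from a double-bonded chain carbon.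

Going by the values given here, no measured pair of compounds differs in one place only, so the size of this change cannot be read from a direct precedent. A modest step towards weaker growth inhibition is expected in this assay, and a reading at the limit of the assay remains possible. The expected change is a 2.0-fold higher number from compound 1 to compound 3 (0.31 log units; beyond the scatter). Compound 3 is estimated at 6 ug/mL, with an expected range of 2 ug/mL to 20 ug/mL.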

Compound 3, concentration for 50% growth inhibition: > 10 ug/mL
Compound 3 gave a limit, no number; the forecaster's own chance of this, stated with the estimate: 35%; at least 1.6-fold (0.22 log units) between middle value and limit.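

In this assay, compound 3 gives > 10 ug/mL, which is a limit of the assay and not a number. Setting 8-acetamidooctyl in place of pentyloxy on a saturated chain carbon, seven bonds along the chain from a double-bonded chain carbon, is the only change at this place that can be read against a number, and it gives an at least 3.3-fold higher number from compound 1 to compound 3 (0.52 log units; beyond the scatter), so growth inhibition is weaker by more than the scatter. Only the lower end of this step can be read, and its full size stays unknown: the limit of > 10 ug/mL in this assay, at which 2 of the 3 values shown sit.

The compounds shown leave open which part of the entering group goes with the weaker growth inhibition, the octyl chain or the acetamido group. A plain octyl group or an 8-aminooctyl group in the same place would separate these two parts, while a butoxy group would show how the read-out follows a smaller change to the pentyloxy group of compound 1.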